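The source may report more compounds than this note shows. Statements on the series, on what has been measured and on what is new or still open speak of the compounds shown alone.

Measured so far in a functional assay on CCRF-CEM cells (Homo sapiens) for inhibition; a higher number here means a weaker inhibitor, a lower number a stronger inhibitor:

compound 1, `O=C1/C(=C/c2cccc(Cl)c2)Cc2ccccc21`, gives 31800 nM
compound 2, `O=C1/C(=C/c2cccc(Br)c2)Cc2ccccc21`, gives 32400 nM
compound 3, `O=C1CCCCC/C1=C\c1ccc(Cl)cc1`, gives 43500 nM

Among the compounds with values here, the one matched pair is compound 1 to compound 2: bromo in place of chloro on an aromatic carbon. The step is a 1.0-fold higher number from compound 1 to compound 2 (0.01 log units; within the scatter), so the two halogens give numbers that cannot be told apart here. Compound 3 is built on a different core; how the core of compound 3 differs from the core of compound 1 is not broken down here. Compound 3 and compound 2 lie within the scatter of each other, and the same holds for compound 3 against compound 1, so no order among the three is claimed.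

Compound 4, `O=C1CCCCC/C1=C\c1ccc(Br)cc1`, is not yet measured. It stands to compound 3 as compound 2 stands to compound 1: bromo in place of chloro on an aromatic carbon. The two cases are the same kind of change, not the same change: in the first pair the halogen sits meta to a large group, in the second para to a group of 9 heavy atoms. With only one earlier case, the expectation rests on compound 1 and compound 2 showing a 1.0-fold higher number from compound 1 to compound 2 (0.01 log units; within the scatter), and on compound 3 at 43500 nM. A step of a 1.0-fold higher number from compound 3 to compound 4 (0.00 log units; within the scatter) is therefore expected in this assay for compound 4. The estimate for compound 4 is 44000 nM, between 25000 nM and 80000 nM.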

Compound 4, half-maximal inhibitory concentration: 42800 nM
Compound 4: the middle estimate sits 1.0-fold (0.01 log units) above what was measured, within the range that was stated.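

In this assay, bromo in place of chloro on an aromatic carbon gives a 1.0-fold lower number from compound 3 to compound 4 (0.01 log units; within the scatter), so the two halogens cannot be told apart on the core of compound 3. Set beside the earlier pair, the two steps agree: the same change on two cores in this assay, a 1.0-fold higher number (0.01 log units; within the scatter) from compound 1 to compound 2 and a 1.0-fold lower number (0.01 log units; within the scatter) from compound 3 to compound 4, 1.0-fold (0.02 log units) apart, within the scatter of two such steps. This shows that the change carries across these two cores without a readable step, including the case where the halogen is para to a group of 9 heavy atoms, but it does not show that the same would hold on a further core or at another place on the ring.

Going by these compounds, only chloro and bromo appear on the aromatic ring, and it remains open whether a methoxy, an amine or a carboxylic acid in that place would give a number apart from these. No pair shown differs in the core alone, and the part played by the core stays open.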